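Swapping One Aryl Group on a Carbonyl Carbon

This account rests on a few compounds, and the source may have more. Where it says the series, first, only, none or still open, it means among the compounds named here.

In a functional assay on K562 cells (Homo sapiens) for cytotoxicity, read by MTT assay (on this read-out lower numbers stand for stronger inhibition and higher numbers for weaker inhibition), compound 1 `COc1ccc(/C=C/C(=O)c2ccc(OC)c3c2OC(C)(C)C=C3)cc1OC(=O)C(C)C` gives 570 nM and compound 2 `COc1cccc(C(=O)Oc2cc(/C=C/C(=O)c3ccc(OC)c4c3OC(C)(C)C=C4)ccc2OC)c1` gives 790 nM. These two numbers lie within the usual scatter of repeated measurements, so compound 2 stands level with compound 1 on the evidence so far.

Compound 3 `COc1ccc(/C=C/C(=O)c2ccc(OC)c3c2OC(C)(C)C=C3)cc1OC(=O)c1ccc(Br)cc1` has not yet been measured. It keeps the shared core of compound 2 and differs in one group: 4-bromophenyl in place of 3-methoxyphenyl on a carbonyl carbon. In words, it carries 4-bromophenyl in place of 3-methoxyphenyl on a carbonyl carbon.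

Among the compounds with values here, only one measured step bears on this change, and it sits at the same place: a 1.4-fold higher number from compound 1 to compound 2 (0.14 log units; within the scatter), with 3-methoxyphenyl in place of isopropyl. Within the data shown here, that single step is thin evidence, and no measured compound yet carries bromine. Still, it gives no reason to expect a large move in this assay. The expected change is no more than the scatter, an estimated 1.2-fold lower number from compound 2 to compound 3 (0.08 log units; within the scatter). For compound 3 the estimated value is 650 nM, with an expected range from 280 nM to 1500 nM.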

Compound 3, half-maximal inhibitory concentration: 1110 nM
The estimate for compound 3 lay 1.7-fold (0.23 log units) below the measured number, and the stated range covers the measured number.
By their numbers in this assay, from the lowest: compounds 1, 2 and 3 (each within the scatter of the next).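

In this assay, 4-bromophenyl in place of 3-methoxyphenyl on this carbonyl carbon gives a 1.4-fold higher number from compound 2 to compound 3 (0.15 log units; within the scatter), so a ring carrying bromine and a ring carrying methoxy cannot be told apart here. Set against the open isopropyl group, 4-bromophenyl gives a 1.9-fold higher number from compound 1 to compound 3 (0.29 log units; within the scatter), which means that isopropyl, 3-methoxyphenyl and 4-bromophenyl all stand level at this position, and none of the three steps among them goes beyond the scatter. Nothing measured here speaks to what lies behind these numbers.

As far as these compounds go, the three compounds show only one open chain and two substituted phenyl rings on this carbonyl carbon, so it remains open whether a longer chain, a ring bearing an amine or a ring bearing a carboxylic acid would stay level with them or move the number beyond the scatter. From the compounds shown here alone, it also remains open whether an amide link in place of the ester oxygen would leave the number level, and whether these three groups would stay level on other cell types.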